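The source may hold more compounds than are shown below. What is called first, only, known or untested is meant among the compounds shown, and "the series" means these compounds.

Measured so far in a functional assay on the whole organism (strain Wistar Albino) for inhibition, with Rattus norvegicus as the target, read by paw edema, with a stated time of 2 h, at a dose of 20 mg/kg; a lower number here means less inhibition, a higher number more inhibition at the dose given (going by the name of the read-out):

compound 1 `COc1ccc(Cc2nnc3n2NC(c2ccc[nH]2)S3)cc1OC` — 15.9%
compound 2 `Cc1occc1-c1nnc2n1NC(c1ccc[nH]1)S2` — 18.2%
compound 3 `COc1ccc(Cc2nnc3n2NC(c2cccn2C)S3)cc1OC` — 15.8%

All three numbers lie within the usual scatter of one another, so no ordering among compounds 1, 2 and 3 is claimed. Going by the values given here, the one counted change, from compound 1 to compound 3, is methyl in place of hydrogen on an aromatic nitrogen; it gave a number 0.1 percentage points lower from compound 1 to compound 3 (within the scatter), a step that is flat within this assay. How the core of compound 2 differs from the core of compound 1 is not broken down here; the values of compound 2 and compound 3 simply show numbers within the scatter of each other.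

Compound 4 `Cc1occc1-c1nnc2n1NC(c1cccn1C)S2` is not yet measured. It stands to compound 2 as compound 3 stands to compound 1: the change is methyl in place of hydrogen on an aromatic nitrogen, the same change as before, since the place is described in the same words in both cases. Because the earlier step of a number 0.1 percentage points lower from compound 1 to compound 3 (within the scatter) was flat, the step from compound 2 to compound 4 is expected to be small as well, about a number 0.2 percentage points lower from compound 2 to compound 4 (within the scatter) in this assay. Compound 4 is therefore estimated at 18% in this assay, with a likely range from 10% to 26%.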

Compound 4, a percentage reported as inhibition, in the whole organism at one dose (the size of the read-out at that dose, not a potency): 18.9%
Estimate against measurement, compound 4: 0.9 percentage points below; measured number inside the range.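

In this assay, methyl in place of hydrogen on an aromatic nitrogen, the change from 1H-pyrrol-2-yl to 1-methyl-1H-pyrrol-2-yl, gave a number 0.7 percentage points higher from compound 2 to compound 4 (within the scatter). Set beside the earlier step, the change reads as flat on both cores, with no difference between the cores: the same change on two cores in this assay, a number 0.1 percentage points lower (within the scatter) from compound 1 to compound 3 and a number 0.7 percentage points higher (within the scatter) from compound 2 to compound 4, 0.8 percentage points apart, within the scatter of two such steps. This supports carrying the change between these two cores as a flat step at this single dose and time, but it does not show that the change would stay flat on any other core, and a read-out at one dose gives no measure of potency.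

The compounds shown leave open whether ethyl, a longer chain, or a chain ending in an amine or a carboxylic acid on that aromatic nitrogen would move the read-out beyond the scatter. They also leave open whether methyl on that nitrogen stays flat on a third core.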